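Moving the Ring Nitrogen in an Oxazole Ketone Series

The source may report more compounds than this note shows. Statements on the series, on what has been measured and on what is new or still open speak of the compounds shown alone.

Three compounds have been measured so far:
Compound 1, `CCCCCCCC/C=C\CCCCCCC(=O)c1ncc(-c2ccoc2)o1`, gives 610 nM in an assay on isolated protein for inhibition of Fatty-acid amide hydrolase 1 (Homo sapiens); a higher number here means a weaker inhibitor, a lower number a stronger inhibitor.
Compound 2, `CCCCCCCC/C=C\CCCCCCC(=O)c1ncc(-c2ccccc2)o1`, gives 320 nM in this assay.
Compound 3, `CCCCCCCC/C=C\CCCCCCC(=O)c1ncc(-c2ccncc2)o1`, gives 56 nM in this assay.

All three share the same long-chain ketone attached to a five-membered aromatic core, and differ only in the aromatic ring hanging from that core. Compound 3 stands lowest of the three numbers. Its nearest neighbour is compound 2, with a 5.7-fold lower number from compound 2 to compound 3 (0.76 log units; beyond the scatter), and its furthest is compound 1, with an 11-fold lower number from compound 1 to compound 3 (1.04 log units; beyond the scatter). The remaining step, a 1.9-fold lower number from compound 1 to compound 2 (0.28 log units; within the scatter), is too small to read as a real difference.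

Compound 4, `CCCCCCCC/C=C\CCCCCCC(=O)c1ncc(-c2cccnc2)o1`, is the next compound. The change is pyridin-3-yl in place of pyridin-4-yl on an aromatic carbon. Compound 3 and compound 4 thus have exactly the same atoms, and only the placement of the nitrogen within the six-membered ring differs.

Going by the values given here, none of the measured steps swaps one pyridyl ring for another, so there is no direct guide. What the steps do show is that the choice of the hanging ring can shift the number a good deal, as seen in an 11-fold lower number from compound 1 to compound 3 (1.04 log units; beyond the scatter) and a 5.7-fold lower number from compound 2 to compound 3 (0.76 log units; beyond the scatter). Because compound 3 already gives 56 nM, the lowest number seen, a modest drift to a higher number is the expected outcome for compound 4, with a step of about a 1.8-fold higher number from compound 3 to compound 4 (0.25 log units; within the scatter) expected. For compound 4 the estimate is 100 nM, expected to lie between 30 nM and 400 nM.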

Compound 4, inhibition constant: 61 nM
For compound 4 the middle estimate is 1.6-fold (0.21 log units) above the measured one; low and high end bracket the measured number.
By their numbers in this assay, from the lowest: compounds 3 and 4 (each within the scatter of the next); then compounds 2 and 1 (each within the scatter of the next).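

Moving the ring nitrogen, with pyridin-3-yl in place of pyridin-4-yl, leaves the number in this assay unchanged within the scatter (a 1.1-fold higher number from compound 3 to compound 4 (0.04 log units; within the scatter)), so the placement of the nitrogen cannot be told apart between these two rings. The advantage of a pyridyl ring therefore does not depend on one nitrogen placement, since the pyridin-3-yl ring also stands clear of phenyl (a 5.2-fold lower number from compound 2 to compound 4 (0.72 log units; beyond the scatter)) and of furan-3-yl (a 10-fold lower number from compound 1 to compound 4 (1.00 log units; beyond the scatter)), just as pyridin-4-yl does. The compounds at hand come with no outside data that could explain why the two pyridyl rings match each other or why they stand apart from the other two rings.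

Still open, from the compounds shown here alone, is how a pyridin-2-yl ring would behave at this same place on the core, and whether a pyrimidine ring, or an amine or a carboxylic acid carried on the pyridyl ring, would move the number further. The long chain and its ketone stay the same throughout, so it is also unknown whether the match between the two pyridyl rings would hold with a shorter chain.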